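A few compounds are considered here, and "the series" means these few. Any claim that something is new, unique, unknown or untested is made for them only; others in the source may bear on it.

In an ADME assay on MT4 cells (Homo sapiens) for cytotoxicity, read by MTT assay, with a stated time of 4 days (a higher number here means that more compound is tolerated, a lower number that less compound is tolerated), compound 3 (`CC(=O)Nc1ccc2oc(-c3ccc(F)cc3)c(O)c(=O)c2c1`) gives 34100 nM. That places it with compound 1 (`COc1cccc(-c2oc3ccc(NC(C)=O)cc3c(=O)c2O)c1`), which gives 33300 nM, the two being separated by a 1.0-fold higher number from compound 1 to compound 3 (0.01 log units; within the scatter). Compound 2 (`COc1ccc(-c2oc3ccc(NC(C)=O)cc3c(=O)c2O)cc1`) gives 98700 nM, and the measured change to the third compound is a 2.9-fold lower number from compound 2 to compound 3 (0.46 log units; beyond the scatter).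

Compound 4 (`COc1c(-c2ccc(F)cc2)oc2ccc(NC(C)=O)cc2c1=O`) is compound 3 with one change: methyl in place of hydrogen on an oxygen on an aromatic ring, or hydroxy to methoxy. Among the compounds with values here, no measured pair makes this change, so the evidence is indirect. All three measured steps alter the group on an aromatic carbon and leave that hydroxy in place. The largest are modest, namely a 3.0-fold higher number from compound 1 to compound 2 (0.47 log units; beyond the scatter) for 4-methoxyphenyl in place of 3-methoxyphenyl, together with the fluoro-for-methoxy step from compound 2. The swap of 3-methoxyphenyl for 4-fluorophenyl stays within the scatter. The data therefore show only that this series has so far moved little, and they give no direction for the new change.

The expected result is a 1.5-fold higher number from compound 3 to compound 4 (0.17 log units; within the scatter), a small estimated step that is not expected to clearly exceed the scatter. For compound 4 the estimate is 50000 nM, with an expected range from 16000 nM to 150000 nM.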

Compound 4, half-maximal cytotoxic concentration: 317000 nM
The estimate for compound 4 lay 6.3-fold (0.80 log units) below the measured number; measured number above the stated range.
By their numbers in this assay, from the lowest: compounds 1 and 3 (each within the scatter of the next); then compound 2; then compound 4.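

In this assay, the change from hydroxy to methoxy, with methyl in place of hydrogen on an oxygen on an aromatic ring, gives a 9.3-fold higher number from compound 3 to compound 4 (0.97 log units; beyond the scatter) and shows that this oxygen is a place where a single change moves the number upward, toward more compound being tolerated. The earlier compounds all keep the hydroxy and vary only the group on the aromatic carbon, and the largest of their steps, a 3.0-fold higher number from compound 1 to compound 2 (0.47 log units; beyond the scatter), is smaller than the step seen here, so the oxygen has a larger effect in this one pair than any aryl change shown. No measurement here explains why capping this oxygen has this effect.

From the compounds shown here alone, the step rests on one pair with the 4-fluorophenyl group, so it remains open whether methoxy would raise the number to a similar extent alongside the 3-methoxyphenyl or 4-methoxyphenyl group of compound 1 or compound 2. Also open, going by these compounds, is how this number would respond to a longer chain on the same oxygen, such as ethoxy, or to an acetate ester or an amine in place of the hydroxy.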